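From Phenoxy to Pyrrolidinyl on the Shared Core

The source may report more compounds than this note shows. Statements on the series, on what has been measured and on what is new or still open speak of the compounds shown alone.

Compound 3 `Cc1cc(Oc2ccccc2)c(S(C)(=O)=O)cc1C(=O)N=C(N)N` gives 10 nM in a functional assay for inhibition of sodium/hydrogen exchanger (Oryctolagus cuniculus) (a higher number here means a weaker inhibitor, a lower number a stronger inhibitor), the lowest of the three numbers shown, though all three sit within the scatter of one another: compound 1 `Cc1cc(Br)c(S(C)(=O)=O)cc1C(=O)N=C(N)N` gives 12 nM and compound 2 `Cc1cc(OC(C)C)c(S(C)(=O)=O)cc1C(=O)N=C(N)N` gives 19 nM. Both steps into compound 3 were small, a 1.2-fold lower number from compound 1 to compound 3 (0.08 log units; within the scatter) and a 1.9-fold lower number from compound 2 to compound 3 (0.28 log units; within the scatter), as was a 1.6-fold higher number from compound 1 to compound 2 (0.20 log units; within the scatter). Compound 4 `Cc1cc(N2CCCC2)c(S(C)(=O)=O)cc1C(=O)N=C(N)N` carries pyrrolidin-1-yl in place of phenoxy on an aromatic carbon. Among the measured compounds shown here, no measured step exchanges an oxygen-linked group for a nitrogen-linked ring at this carbon, so those three small steps are the only guide, and bromo, isopropoxy and phenoxy all gave similar numbers. For compound 4 the step expected is a 1.5-fold higher number from compound 3 to compound 4 (0.18 log units; within the scatter), nothing beyond the scatter. Compound 4 is therefore estimated at 15 nM, with a range from 5 nM to 45 nM.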

Compound 4, half-maximal inhibitory concentration: 11 nM
The estimate for compound 4 lay 1.4-fold (0.13 log units) above the measured number; the range from low to high includes it.
By their numbers in this assay, from the lowest: compounds 3, 4, 1 and 2 (each within the scatter of the next).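

In this assay a nitrogen-linked pyrrolidin-1-yl ring on this aromatic carbon, ortho to a methylsulfonyl group, reads as a 1.1-fold higher number from compound 3 to compound 4 (0.04 log units; within the scatter) and as a 1.7-fold lower number from compound 2 to compound 4 (0.24 log units; within the scatter) and as a 1.1-fold lower number from compound 1 to compound 4 (0.04 log units; within the scatter) in the other two comparisons. The position has now taken bromo, two oxygen-linked groups and a non-aromatic nitrogen-linked ring with no step beyond the scatter. Nothing available explains why these groups give such similar numbers. The compounds shown leave open whether a carboxylic acid, a primary amine or a longer alkyl chain at this carbon would stay within the same narrow band.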